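This account rests on a few compounds, and the source may have more. Where it says the series, first, only, none or still open, it means among the compounds named here.

Measured compounds in the series:

compound 1, `COc1ccc(CNc2nc(SC)nc3ccccc23)cc1`: 30900 nM
compound 2, `CSc1nc(NCc2ccccc2)c2ccccc2n1`: 41500 nM

In a functional assay on MCF7 cells (Homo sapiens) for cytotoxicity, read by MTT assay, with a stated time of 72 h (a higher number here means a weaker inhibitor of growth, a lower number a stronger inhibitor of growth), compound 2 gives 41500 nM, the higher of the two numbers on hand. For the measured compounds named here, the only neighbour is compound 1, which gives 30900 nM in this assay; the step of a 1.3-fold higher number from compound 1 to compound 2 (0.13 log units; within the scatter) is within the scatter, so the two compounds are not separated, and the change of hydrogen in place of methoxy on an aromatic carbon has no effect that can be read.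

Compound 3, `CSc1ccc(CNc2nc(SC)nc3ccccc23)cc1`, has not yet been measured in this assay. It differs from compound 2 by methylsulfanyl in place of hydrogen on an aromatic carbon, the methylsulfanyl sitting on an aromatic carbon of a six-membered aromatic ring of carbon only, para to a large group. Going by the values given here, the one measured step that bears on this position, a 1.3-fold higher number from compound 1 to compound 2 (0.13 log units; within the scatter), was within the scatter, so a group at this carbon has so far made no difference that can be seen. On that basis the step from compound 2 to compound 3 is expected to be small: a 1.3-fold lower number from compound 2 to compound 3 (0.10 log units; within the scatter), likely none beyond the scatter. Compound 3 is therefore estimated at 33000 nM in this assay, in a range of 12000 nM to 90000 nM.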

Compound 3, concentration for 50% growth inhibition: 47300 nM
Estimate against measurement, compound 3: 1.4-fold (0.16 log units) below; the range from low to high includes it.
By their numbers in this assay, from the lowest: compounds 1, 2 and 3 (each within the scatter of the next).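

In this assay, for the compounds shown here, the first group with sulfur at this carbon, methylsulfanyl on an aromatic carbon para to a large group, gives a 1.1-fold higher number from compound 2 to compound 3 (0.06 log units; within the scatter), so the absence of a visible effect now holds for a second substituent and not only for methoxy. The exchange of one group for the other gives a 1.5-fold higher number from compound 1 to compound 3 (0.18 log units; within the scatter), which means that hydrogen, methoxy and methylsulfanyl at this carbon are all within the scatter of one another and none of the three can be ranked in this assay. No supporting measurement on hand offers an explanation for this flat result.

As far as these compounds go, whether an amine or a carboxylic acid at this carbon, or a longer chain such as butoxy, would give a step beyond the scatter remains open, as the three compounds cover only hydrogen and two small groups. Also open, from the compounds shown here alone, is whether a change elsewhere on the shared core, away from this carbon, would move the number in this assay at all.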